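The source may hold more compounds than are shown below. What is called first, only, known or untested is meant among the compounds shown, and "the series" means these compounds.

Compound 3 `CCOC(=O)CCCCCOc1cccc(CN(C(=O)c2ccc(-c3ccco3)cc2)C(C)C)c1` stands among three compounds that share a core, all of them tested in an ADME assay on HEK293 cells (Homo sapiens) for cytotoxicity, read by CellTiter-Glo and resazurin assay, with a stated time of 72 h; a lower number here means that less compound is needed, a higher number that more compound is needed for the effect. In this assay compound 3 gives > 26000 nM, which is a limit of the assay rather than a number. Compound 1 `CC(C)N(Cc1cccc(OCCCCCC(=O)O)c1)C(=O)c1ccc(-c2ccco2)cc1` likewise gives > 26000 nM, a limit. Compound 2 `CC(C)N(Cc1cccc(OCCCCCC(=O)O)c1)C(=O)c1ccc(-c2cccc(F)c2)cc1` gives > 26000 nM, also a limit. The step that the two limits leave unreadable from compound 1 to compound 2 therefore cannot be sized, and the same holds for a step that the two limits leave unreadable from compound 1 to compound 3; every measured value sits at the limit described by the limit of > 26000 nM in this assay, at which 3 of the 3 values shown sit, so nothing among the three points to any readable trend.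

Compound 4 `CCOC(=O)CCCCCOc1cccc(CN(C(=O)c2ccc(-c3cccc(Br)c3)cc2)C(C)C)c1` carries the change (3-bromophenyl in place of furan-2-yl on an aromatic carbon). Among the compounds with values here, the only step that bears on it, the replacement of the same furan-2-yl by 3-fluorophenyl from compound 1 to compound 2, left no readable size, and the ethyl ester is common to compounds 3 and 4. Compound 3 to compound 4 is thus expected to show a step that the limit leaves unreadable from compound 3 to compound 4, nothing beyond the scatter, and compound 4 is estimated at 40000 nM in this assay, within 20000 nM to 120000 nM, most likely reported again only as a limit.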

Compound 4, half-maximal effective concentration: > 26000 nM
Compound 4: no number, only a limit (the forecaster's own chance of this, stated with the estimate: 85%); the middle value lies beyond the limit too.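

Within the data shown here, compound 3 and compound 4 both stand at a limit rather than a number, so no step between them can be read: the limit of > 26000 nM in this assay, at which 4 of the 4 values shown sit.

The compounds shown leave open whether furan-2-yl and 3-bromophenyl differ at all in this assay, and at what concentration any of the four compounds would reach the effect.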